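A few compounds are considered here, and "the series" means these few. Any claim that something is new, unique, unknown or untested is made for them only; others in the source may bear on it.

The study examines a small set of acylthiourea derivatives built on a fused bicyclic core. Compound 1 `CCCCC(=O)NC(=S)Nc1nc2cc(Br)ccc2s1` carries bromo on the aromatic carbon of its core, while compound 2 `CCCCC(=O)NC(=S)Nc1nc2ccccc2s1` carries hydrogen at that place; the difference between them is hydrogen in place of bromo on an aromatic carbon. In a functional assay on HeLa cells (Homo sapiens) for cytotoxicity, read by MTT assay, with a stated time of 24 h (a higher number here means a weaker inhibitor, a lower number a stronger inhibitor), compound 1 gives 60200 nM, and in the same setting compound 2 gives 56700 nM, so the step of a 1.1-fold lower number from compound 1 to compound 2 (0.03 log units; within the scatter) is small and lies within the usual scatter.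

Compound 3 `O=C(NC(=S)Nc1nc2cc(Br)ccc2s1)c1ccc([N+](=O)[O-])cc1` keeps the bromo of compound 1 but bears a different acyl part; the difference between the two cores is not broken down here. In this assay compound 3 gives 56500 nM, a number that sits within the scatter of the values of compound 1 and compound 2, so no order among the three can be claimed.

Compound 4 `O=C(NC(=S)Nc1nc2ccccc2s1)c1ccc([N+](=O)[O-])cc1` has not yet been measured. Within the data shown here, it differs from compound 3 by hydrogen in place of bromo on an aromatic carbon, the same change, at the same place, as the one that separates compound 1 from compound 2; among the compounds described, this change occurs two times in all. The earlier instance, a 1.1-fold lower number from compound 1 to compound 2 (0.03 log units; within the scatter), produced a step within the scatter. Among the measured compounds shown here, on that basis a similarly small step is expected in this assay from compound 3 to compound 4, namely a 1.0-fold lower number from compound 3 to compound 4 (0.02 log units; within the scatter), because the only precedent gave a 1.1-fold lower number from compound 1 to compound 2 (0.03 log units; within the scatter). Compound 4 is therefore estimated at 54000 nM, with a plausible range from 27000 nM to 108000 nM.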

Compound 4, half-maximal inhibitory concentration: 62600 nM
Estimate against measurement, compound 4: 1.2-fold (0.06 log units) below, and the stated range covers the measured number.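

In this assay, among these compounds, hydrogen in place of bromo on an aromatic carbon gives a 1.1-fold higher number from compound 3 to compound 4 (0.04 log units; within the scatter), so on this second core the change leaves no step that can be told from the scatter. Set beside the earlier instance of the same change, the new step does not differ from it, and the result carries across the two cores with their different acyl parts as a lack of any readable step: the same change on two cores in this assay, a 1.1-fold lower number (0.03 log units; within the scatter) from compound 1 to compound 2 and a 1.1-fold higher number (0.04 log units; within the scatter) from compound 3 to compound 4, 1.2-fold (0.07 log units) apart, within the scatter of two such steps This shows only that removing bromo from this place makes no readable difference on these two cores in this one assay; it does not show that the change has a real effect of a fixed size or direction, and two small steps cannot establish that the same would hold on any further core in the series.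

What the compounds shown leave open is whether chloro, methoxy or an amine on the same aromatic carbon would give a step beyond the scatter. On these data alone, it also remains open whether bromo and hydrogen would still match on a core whose acyl part carries a carboxylic acid or a longer chain.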